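The compounds below may be only part of what the source reports. "The series", "measured", "known", "first", "only" and "open" are said of these compounds alone.

Measured so far:
- compound 1 `COc1cc(-c2cc(/C=C/C(=O)c3ccc(N)cc3)[nH]n2)cc(OC)c1OC`: 102%
- compound 2 `COc1ccc(-c2cc(/C=C/C(=O)c3ccc(OC)c(OC)c3)[nH]n2)cc1`: 105%
- compound 3 `COc1ccc(-c2cc(/C=C/C(=O)c3ccc(N)cc3)[nH]n2)cc1OC`: 102%

All three values in a functional assay on KM12 cells (Homo sapiens) for cytotoxicity, read by sulforhodamine B assay, with a stated time of 48 h, tested at 0.01 uM (on this read-out higher numbers stand for a weaker effect at the one concentration tested and lower numbers for a stronger effect), lie within the scatter of one another. Compound 1 stands level with compound 3 at the digits shown, and compound 2 also sits within the scatter of compound 1; none of the three shows a measurable effect at the concentration tested.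

Compound 4 `COc1ccc(C(=O)/C=C/c2cc(-c3cc(OC)c(OC)c(OC)c3)n[nH]2)cc1` is the next member. Relative to compound 1 the change is methoxy in place of amino on an aromatic carbon. Going by the values given here, no measured pair covers this exchange. Among the compounds with values here, the only step in hand, no change at the digits printed from compound 1 to compound 3 (within the scatter), removes a methoxy on the other aryl ring and leaves the read-out unchanged. Compound 2, which carries methoxy rather than amino on the ketone-side ring in a different pattern, also sits within the scatter of compound 1. Nothing therefore points to a step beyond the scatter, in either direction.

For compound 4 the expected step is a number 1 percentage points higher from compound 1 to compound 4 (within the scatter). Compound 4 is accordingly estimated at 103%, with a range from 93% to 113%.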

Compound 4, a percentage reported as activity, at one concentration (the size of the read-out at that concentration, not a potency): 99%
The estimate for compound 4 lay 4 percentage points above the measured number; the range from low to high includes it.
By their numbers in this assay, from the lowest: compounds 4, 1, 3 and 2 (each within the scatter of the next).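

In this assay, going by these compounds alone, replacing 4-aminophenyl with 4-methoxyphenyl gives a number 3 percentage points lower from compound 1 to compound 4 (within the scatter), the first direct reading of this exchange at this position, para to a large group. At the one concentration tested, the read-out does not separate amino from methoxy on this ring, so this pair shows no sensitivity to the change. No available evidence bears on why the read-out stays flat across this exchange.

Still open, as far as these compounds go, is whether another group at this position, such as hydroxy, dimethylamino or a carboxylic acid, would separate from amino and methoxy in this assay. Also open, from the compounds shown here alone, is whether compound 1 and compound 4 would part at a higher concentration, since a single concentration with no measurable effect says nothing about their potency.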